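The compounds below may be only part of what the source reports. "The series", "measured", "known", "first", "only" and "open" are said of these compounds alone.

Working notes on the series. In a functional assay on PC-3 cells (Homo sapiens) for cytotoxicity, read by colorimetric assay and MTT assay (on this read-out higher numbers stand for weaker inhibition and lower numbers for stronger inhibition), compound 1 (`COc1cc(OC)c2cc(-c3ccccc3)c(O)nc2c1`) gives 10000 nM. Compound 2 (`CCN(CC)C(=O)Cn1c(=O)c(-c2ccc(OC)cc2)cc2c(OC)cc(OC)cc21`) gives 10000 nM, so the two stand level, with no difference at the digits reported. Among the measured compounds shown here, these are the only two measurements so far, and neither compound can be ranked over the other.

Compound 3 (`COc1ccc(-c2cc3c(OC)cc(OC)cc3n(CCCC#N)c2=O)cc1`) has not yet been measured. Its difference from compound 2 is 2-cyanoethyl in place of diethylcarbamoyl on a saturated chain carbon bound to an aromatic nitrogen. In words, this is 2-cyanoethyl in place of diethylcarbamoyl on a saturated chain carbon bound to an aromatic nitrogen. Cut one bond further out, the same difference reads (diethylcarbamoyl)methyl to 3-cyanopropyl.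

For the measured compounds named here, no measured pair shows the effect of a change at this place, so the only guide is the shared level of the two measured compounds. The expectation rests on compound 2 at 10000 nM. No step beyond the scatter is expected in this assay, and neither direction is favoured. The estimated step is no change at the digits printed from compound 2 to compound 3 (within the scatter). For compound 3 the expected value is 10000 nM, with an estimated range of 4000 nM to 20000 nM.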

Compound 3, half-maximal inhibitory concentration: 10000 nM
Compound 3: the middle estimate sits on the measured number at the digits printed; low and high end bracket the measured number.
By their numbers in this assay, from the lowest: compounds 1, 2 and 3 (each within the scatter of the next).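

In this assay, the first step readable at this place, 2-cyanoethyl in place of diethylcarbamoyl on a saturated chain carbon bound to an aromatic nitrogen, comes out as no change at the digits printed from compound 2 to compound 3 (within the scatter). The number therefore does not separate the two side chains, even though a group of 7 heavy atoms with a double bond outside aromatic rings leaves and a group of 4 heavy atoms with a triple bond enters. No supporting measurement bears on why the two compounds read alike.

From the compounds shown here alone, whether a primary amine, a carboxylic acid or a longer chain ending in a nitrile at this place would separate from compound 3 in this assay remains open. Going by these compounds, with a single step at a single place, it is also open whether the same exchange would read alike on a different core, so the result holds only for compound 2 and compound 3.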